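The compounds below may be only part of what the source reports. "The series", "measured", "known", "first", "only" and "open" are said of these compounds alone.

Compound 3 `CC/C=C\C(=O)Nc1cc(Nc2ncc(C#N)c(-c3cn(C)c4ccc(F)cc34)n2)c(OC)cc1N(C)CCN(C)C` gives 5880 nM in a functional assay on HepG2 cells (Homo sapiens) for antiproliferative activity, read by MTT assay, with a stated time of 72 h; on this read-out lower numbers stand for stronger inhibition and higher numbers for weaker inhibition. Among the three compounds measured so far it holds the second highest number: compound 2 `C=CC(=O)Nc1cc(Nc2ncc(C#N)c(-c3cn(C)c4ccc(F)cc34)n2)c(OC)cc1N(C)CCN(C)C` gives 17500 nM, and compound 1 `CCC/C=C\C(=O)Nc1cc(Nc2nccc(-c3cn(C)c4ccc(F)cc34)n2)c(OC)cc1N(C)CCN(C)C` gives 3400 nM. Compound 4 `CCC/C=C\C(=O)Nc1cc(Nc2ncc(C#N)c(-c3cn(C)c4ccc(F)cc34)n2)c(OC)cc1N(C)CCN(C)C` differs from compound 3 by methyl in place of hydrogen on a saturated chain carbon, two bonds along the chain from a double-bonded chain carbon. Among the compounds with values here, one measured step bears on this change: the step of a 3.0-fold lower number from compound 2 to compound 3 (0.47 log units; beyond the scatter), in which the chain on the carbonyl carbon was lengthened. Compound 1 also carries the pent-1-en-1-yl chain, though without the nitrile, and its number is lower than that of compound 3. A further lengthening is therefore expected to lower the number modestly, by a 1.5-fold lower number from compound 3 to compound 4 (0.17 log units; within the scatter). Compound 4 is estimated at 4000 nM, with a range from 1500 nM to 11000 nM.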

Compound 4, half-maximal inhibitory concentration: 2010 nM
The estimate for compound 4 lay 2.0-fold (0.30 log units) above the measured number; the range from low to high includes it.
By their numbers in this assay, from the lowest: compounds 4, 1 and 3 (each within the scatter of the next, the first and the last beyond it); then compound 2.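

In this assay, adding methyl in place of hydrogen on the saturated chain carbon gives a 2.9-fold lower number from compound 3 to compound 4 (0.47 log units; beyond the scatter), so the lengthening that began at the shorter chain continues to pent-1-en-1-yl; the whole change from vinyl amounts to an 8.7-fold lower number from compound 2 to compound 4 (0.94 log units; beyond the scatter). With the pent-1-en-1-yl chain held constant, cyano in place of hydrogen on the aromatic carbon gives a 1.7-fold lower number from compound 1 to compound 4 (0.23 log units; within the scatter), which lies within the scatter, so these two compounds cannot be told apart. No measurement here gives a cause for these steps. As far as these compounds go, whether a still longer chain, such as hex-1-en-1-yl, continues this trend remains open. So does the effect of a terminal amine on this chain.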